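The compounds below may be only part of what the source reports. "The series", "measured", "known", "first", "only" and "open" are said of these compounds alone.

Compound 3 `COc1cccc(NC(=O)c2nnn(Cc3ccc(C(C)C)cc3)c2N)c1` stands highest of the three numbers in a physicochemical assay for lipophilicity, read by HPLC, measured as chromatographic lipophilicity, at pH 7.4 (on this read-out lower numbers stand for lower lipophilicity and higher numbers for higher lipophilicity), where compound 3 gives 3.4. Its nearest neighbour is compound 2 `COc1cccc(NC(=O)c2nnn(Cc3ccc(-n4cccn4)cc3)c2N)c1`, which gives 2.4, separated by the step of a number 1.00 log units higher from compound 2 to compound 3 (beyond the scatter). Compound 1 `COc1cccc(NC(=O)c2nnn(CC3CCNCC3)c2N)c1` lies furthest away with 0.6, the gap being a number 2.80 log units higher from compound 1 to compound 3 (beyond the scatter). Compound 4 `COc1cccc(NC(=O)c2nnn(Cc3ccc([S+](C)[O-])cc3)c2N)c1` differs from compound 3 by a group of 3 heavy atoms (1 carbon, 1 oxygen, 1 sulfur; no ring) in place of a group of 3 heavy atoms (3 carbon; no ring), on an aromatic carbon. Of the measured steps, a number 1.00 log units higher from compound 2 to compound 3 (beyond the scatter) exchanges a group on an aromatic carbon and was modest, while a number 2.80 log units higher from compound 1 to compound 3 (beyond the scatter) was large; both point downward when isopropyl is given up, so a drop beyond the scatter in this assay is expected, probably between those two sizes. The expected step is a number 2.40 log units lower from compound 3 to compound 4 (beyond the scatter). Compound 4 is therefore estimated at 1, within a range of 0.3 to 1.7.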

Compound 4, distribution coefficient: 1.3
Estimate against measurement, compound 4: 0.30 log units below; the range from low to high includes it.
By their numbers in this assay, from the lowest: compound 1; then compound 4; then compound 2; then compound 3.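

In this assay, the exchange at this aromatic carbon, para to a large group, moves the number far more than the earlier pyrazole-for-isopropyl step did: the group of carbon, oxygen and sulfur gives a large drop from isopropyl (a number 2.10 log units lower from compound 3 to compound 4 (beyond the scatter)) and also from 1H-pyrazol-1-yl (a number 1.10 log units lower from compound 2 to compound 4 (beyond the scatter)). This single exchange still leaves the compound above the piperidin-4-yl compound (a number 0.70 log units higher from compound 1 to compound 4 (beyond the scatter)). Nothing measured here explains these steps. The compounds shown leave open where an amine or a carboxylic acid on this aromatic carbon would fall in this order.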